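The compounds below may be only part of what the source reports. "The series", "measured", "known", "first", "only" and "open" are said of these compounds alone.

Of the compounds shown here, three built on one shared core have been measured in an assay on HeLa cells for binding affinity to 5-hydroxytryptamine receptor 6 (Homo sapiens); a lower number here means a stronger inhibitor, a higher number a weaker inhibitor. Compound 1 `COc1ccc(NS(=O)(=O)c2cn(C)cn2)cc1N1CCN(C)CC1` carries a 1-methyl-1H-imidazol-4-yl group on the sulfonyl sulfur and gives 794 nM. Compound 2 `COc1ccc(NS(=O)(=O)c2cc(Cl)cc(Cl)c2)cc1N1CCN(C)CC1` carries a 3,5-dichlorophenyl group on that sulfur and gives 2 nM. Compound 3 `COc1ccc(NS(=O)(=O)c2cccc(C#N)c2)cc1N1CCN(C)CC1` carries a 3-cyanophenyl group there and gives 63.1 nM, the second highest of the three numbers. The step of a 13-fold lower number from compound 1 to compound 3 (1.10 log units; beyond the scatter) is large, and the step of a 32-fold higher number from compound 2 to compound 3 (1.50 log units; beyond the scatter) is large as well, so compound 3 sits between the other two, closer to compound 1 than to compound 2.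

Compound 4 `COc1ccc(NS(=O)(=O)c2cccc([N+](=O)[O-])c2)cc1N1CCN(C)CC1` differs from compound 3 in one place: nitro in place of cyano on an aromatic carbon. Among the compounds with values here, none of the measured steps swaps one substituent for another on the same six-membered aromatic ring of carbon only; the steps of a 400-fold lower number from compound 1 to compound 2 (2.60 log units; beyond the scatter), a 13-fold lower number from compound 1 to compound 3 (1.10 log units; beyond the scatter) and a 32-fold higher number from compound 2 to compound 3 (1.50 log units; beyond the scatter) each exchange the whole group on the sulfonyl sulfur, and all of them are large. The exchange of nitro for cyano keeps the phenyl and its substitution pattern, so the step of a 1.3-fold lower number from compound 3 to compound 4 (0.10 log units; within the scatter) is expected to be small, within the scatter or only just beyond it, in either direction. In this assay compound 4 is therefore estimated at 50 nM, with a range from 15 nM to 200 nM.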

Compound 4, inhibition constant: 79.4 nM
Compound 4: the middle estimate sits 1.6-fold (0.20 log units) below what was measured, and the stated range covers the measured number.
By their numbers in this assay, from the lowest: compound 2; then compounds 3 and 4 (each within the scatter of the next); then compound 1.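

In this assay, within the data shown here, the step of a 1.3-fold higher number from compound 3 to compound 4 (0.10 log units; within the scatter) is the first to exchange one substituent for another on the aromatic carbon meta to a large group while the phenyl stays in place, and it lies within the scatter, so this assay does not tell cyano and nitro apart at this position. The 3-nitrophenyl group also stands apart from the two other groups on the sulfonyl sulfur, with the large step of a 40-fold higher number from compound 2 to compound 4 (1.60 log units; beyond the scatter) and the modest step of a 10-fold lower number from compound 1 to compound 4 (1.00 log units; beyond the scatter) showing that compound 4, like compound 3, remains separated from both compound 1 and compound 2 by more than the scatter. Nothing measured on these groups accounts for the close match between cyano and nitro.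

The compounds shown leave open whether other substituents on this carbon, such as an amine, a carboxylic acid or a methoxy group, would also fall within the scatter of compound 3 and compound 4. They also leave open how much of the distance to compound 2 belongs to the chlorine itself and how much to the presence of a second chlorine, which a 3-chlorophenyl group on the sulfonyl sulfur would address.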